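A few compounds are considered here, and "the series" means these few. Any claim that something is new, unique, unknown or untested is made for them only; others in the source may bear on it.

Compound 3 `COc1nc(-c2ccc(C#N)cc2)ccc1[C@@H](c1ccccc1)[C@@](O)(CCN(C)C)c1cccc2ccccc12` was tested in a toxicity assay on HeLa cells (Homo sapiens) for cytotoxicity; on this read-out higher numbers stand for lower toxicity in this test and lower numbers for higher toxicity in this test. In this assay compound 3 gives > 64 ug/mL, which is a limit of the assay and not a number. Compound 2 `COc1nc(-c2ccc(OC(F)(F)F)cc2)ccc1[C@@H](c1ccccc1)[C@@](O)(CCN(C)C)c1cccc2ccccc12` gives > 64 ug/mL in this assay, again only a limit. Compound 1 `COc1nc(-c2cccc(Cl)c2)ccc1[C@@H](c1ccccc1)[C@@](O)(CCN(C)C)c1cccc2ccccc12` gives "nd" (no result reported) in this assay, so no number exists for it at all. Compound 3 therefore stands at the limit of > 64 ug/mL in this assay, at which 2 of the 3 values shown sit, with no single number of its own and nothing measured that it can be ordered against.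

Compound 4 `COc1nc(-c2cccc(F)c2)ccc1[C@@H](c1ccccc1)[C@@](O)(CCN(C)C)c1cccc2ccccc12` differs from compound 3 by 3-fluorophenyl in place of 4-cyanophenyl on an aromatic carbon. Within the data shown here, the only measured step that touches this position, a step that the two limits leave unreadable from compound 2 to compound 3, runs between two limits, so its size cannot be read and it offers no direction. The step that the limit leaves unreadable from compound 3 to compound 4 is expected to stay within the scatter, because both neighbours already rest at the limit of > 64 ug/mL in this assay, at which 2 of the 3 values shown sit. Compound 4 is estimated to give 80 ug/mL in this assay, within 40 ug/mL to 200 ug/mL, and most likely to be reported once more only as a limit.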

Compound 4, half-maximal cytotoxic concentration: 62.8 ug/mL
For compound 4 the middle estimate is 1.3-fold (0.11 log units) above the measured one; measured number inside the range.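

In this assay, among these compounds, compound 4 gives 62.8 ug/mL, the first actual number at this position, next to the ring nitrogen. Its comparison with the two neighbours is still only partial: there is an at least 1.0-fold lower number from compound 3 to compound 4 (0.00 log units; that floor lies within the scatter), and there is an at least 1.0-fold lower number from compound 2 to compound 4 (0.00 log units; that floor lies within the scatter), so neither step shows a real change in toxicity. Compound 2 and compound 3 remain limits of the assay and not numbers: the limit of > 64 ug/mL in this assay, at which 2 of the 4 values shown sit.

In this assay compound 1 gives "nd" (no result reported), which leaves compound 4 with no numerical partner for a comparison at this position. On these data alone, how a phenyl ring carrying an amine or a carboxylic acid would read here in place of 3-fluorophenyl also remains open.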